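Tetrazolyl ketone in place of a pyridyl ketone

The source may report more compounds than this note shows. Statements on the series, on what has been measured and on what is new or still open speak of the compounds shown alone.

Measured so far:
compound 1, `CCCCCCCC/C=C\CCCCCCC(=O)c1ncc(-c2ccccn2)o1`, 18 nM
compound 2, `CCCCCCCC/C=C\CCCCCCC(=O)c1ccccn1`, > 100000 nM
compound 3, `O=C(CCCc1ccccc1)c1nc2ncccc2o1`, 6.9 nM

In an assay on isolated protein for inhibition of Fatty-acid amide hydrolase 1 (Homo sapiens) (on this read-out higher numbers stand for weaker inhibition and lower numbers for stronger inhibition), compound 1 gives 18 nM and compound 3 gives 6.9 nM. Compound 2 gives only a limit, > 100000 nM, which is the limit of > 100000 nM in this assay, at which 1 of the 3 values shown sits; its inhibition is therefore not pinned to a number, and nothing was measured between these three. Compound 4, `CCCCCCCC/C=C\CCCCCCC(=O)c1nnn(C)n1`, is not yet measured. It differs from compound 2 in one place: 2-methyl-2H-tetrazol-5-yl in place of pyridin-2-yl on a carbonyl carbon. Since compound 2 stands at a limit, the account expects the step of an at least 50-fold lower number from compound 2 to compound 4 (1.69 log units; beyond the scatter) to run toward stronger inhibition and to be large, well beyond the scatter. The estimate for compound 4 in this assay is 2000 nM, expected between 200 nM and 20000 nM.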

Compound 4, inhibition constant: 65 nM
Estimate against measurement, compound 4: 31-fold (1.49 log units) above, outside the stated range (below it).
By their numbers in this assay, from the lowest: compound 3; then compound 1; then compound 4. At a limit, above all of these: compound 2.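

In this assay, for the compounds shown here, the one change on a carbonyl carbon gives an at least 1500-fold lower number from compound 2 to compound 4 (3.18 log units; beyond the scatter), so the group at this place alone can separate a ketone with no measurable inhibition from a clear inhibitor. The earlier compounds shown here did not isolate this place, as no two of them formed a one-place pair. The value of compound 2, > 100000 nM, is a limit and not a number, so the true size of the step stays open: the limit of > 100000 nM in this assay, at which 1 of the 4 values shown sits.

On these data alone, whether an amine or a carboxylic acid in place of the methyl of 2-methyl-2H-tetrazol-5-yl would keep this inhibition remains open. So does whether the same change would hold on a shorter chain.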